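The compounds below may be only part of what the source reports. "The series", "measured", "known", "first", "only" and "open" are said of these compounds alone.

Compound 2 `Cc1cc(Cc2cccc(Cl)c2)c(=O)n(CC(=O)Nc2ccc(Br)cc2)n1` belongs to a small set built on a shared core. In an assay on HL-60 cells for agonist activity at N-formyl peptide receptor 3 (Homo sapiens), read by calcium flux (on this read-out higher numbers stand for an effect only at larger amounts of compound and lower numbers for an effect already at smaller amounts), compound 2 gives > 50000 nM, which is a limit of the assay rather than a number. Compound 1 `Cc1cc(Cc2ccccc2)c(=O)n(CC(=O)Nc2ccc(Br)cc2)n1` gives > 50000 nM in this assay, again a limit. Compound 3 `Cc1cc(Cc2ccc(C(N)=O)cc2)c(=O)n(CC(=O)Nc2ccc(Br)cc2)n1` gives > 50000 nM, also a limit. The steps a step that the two limits leave unreadable from compound 1 to compound 2, a step that the two limits leave unreadable from compound 1 to compound 3 and a step that the two limits leave unreadable from compound 2 to compound 3 are thus unreadable, since all three values sit at the limit (the limit of > 50000 nM in this assay, at which 3 of the 3 values shown sit). Compound 4 `Cc1cc(Cc2cccc(Cl)c2)c(=O)n(CC(=O)Nc2ccc(I)cc2)n1` differs from compound 2 by iodo in place of bromo on an aromatic carbon. Among the compounds with values here, no measured step bears on this change, and the three limits give no direction to read. The expected step is a step that the limit leaves unreadable from compound 2 to compound 4, with compound 4 estimated to stay at the limit. Compound 4 is therefore expected to give about 60000 nM, in a range from 20000 nM to 200000 nM.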

Compound 4, half-maximal effective concentration: > 50000 nM
Compound 4: only a limit was reported; the forecaster's own chance of this, stated with the estimate: 85%; the middle value is on the limit's open side.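

No new step can be read from compound 2 to compound 4, since both values are limits: the limit of > 50000 nM in this assay, at which 4 of the 4 values shown sit.

The compounds shown leave open what any of these changes to the shared core does, as none of them gives a value beyond the limit.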